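This account rests on a few compounds, and the source may have more. Where it says the series, first, only, none or still open, it means among the compounds named here.

Within the data shown here, compound 2 `CC(C)C[C@H](N)CN(C(=O)[C@@H]1C[C@H]1c1ccccc1)c1ccc(C2=CCCCC2)cc1` gives 1200 nM in a functional assay for agonist activity at G protein-coupled receptor 88 (Homo sapiens), read by HTRF and cAMP accumulation (a higher number here means that more compound is needed for the effect, a lower number that less compound is needed), the lowest of the two numbers known. Among the measured compounds shown here, compound 1 `CC(C)C[C@H](N)CN(C(=O)[C@@H]1C[C@H]1c1ccccc1)c1ccc(-c2cccnc2)cc1` gives 10000 nM in this assay, and the only measured step, an 8.3-fold lower number from compound 1 to compound 2 (0.92 log units; beyond the scatter), came from the change at the group on the aromatic carbon.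

Compound 3 `Cc1ccccc1-c1ccc(N(C[C@@H](N)CC(C)C)C(=O)[C@@H]2C[C@H]2c2ccccc2)cc1` differs from compound 2 in one place: 2-methylphenyl in place of cyclohex-1-en-1-yl on an aromatic carbon. For the measured compounds named here, no measured step covers an exchange between a non-aromatic and an aromatic carbocycle at this position; the one step available shows only that replacing pyridin-3-yl with cyclohex-1-en-1-yl changed the number well beyond the scatter, so this position is responsive. Because an 8.3-fold lower number from compound 1 to compound 2 (0.92 log units; beyond the scatter) was modest and the new group is a carbocycle like the one it replaces, compound 3 is expected to move little, with a 1.5-fold lower number from compound 2 to compound 3 (0.18 log units; within the scatter). Compound 3 is therefore estimated at 800 nM, within a range of 250 nM to 3000 nM.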

Compound 3, half-maximal effective concentration: 3400 nM
Beside the measured number, compound 3's estimate is 4.3-fold (0.63 log units) below it, and the stated range ends below it.
By their numbers in this assay, from the lowest: compound 2; then compound 3; then compound 1.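

In this assay, this position does not treat its carbocycles alike: exchanging cyclohex-1-en-1-yl for 2-methylphenyl gives a 2.8-fold higher number from compound 2 to compound 3 (0.45 log units; beyond the scatter), so two six-membered rings of carbon only, on the same aromatic carbon, are not interchangeable. Replacing pyridin-3-yl with 2-methylphenyl gives a 2.9-fold lower number from compound 1 to compound 3 (0.47 log units; beyond the scatter), which places all three groups in an order beyond the scatter, with cyclohex-1-en-1-yl giving the lowest number and pyridin-3-yl the highest. Nothing available explains why these groups differ.

The compounds shown leave open whether the higher number with 2-methylphenyl comes with the aromatic ring or with its methyl, a question that unsubstituted phenyl would separate. They also leave open how a fully saturated cyclohexyl or a smaller cyclopentenyl ring would compare with cyclohex-1-en-1-yl.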